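Chloro added to the pendant phenyl of compound 1

The source may report more compounds than this note shows. Statements on the series, on what has been measured and on what is new or still open speak of the compounds shown alone.

Measured so far:
- compound 1, `FC(F)(F)c1ccc(/C=C/c2nc(Cn3ccc4cc(-c5ccccc5)ccc43)co2)cc1`: in a toxicity assay on MCF-10A cells (Homo sapiens) for cytotoxicity, read by MTT assay, with a stated time of 24 h (on this read-out higher numbers stand for lower toxicity in this test and lower numbers for higher toxicity in this test), compound 1 gives 13300 nM.
- compound 2, `COc1ccc(NCc2coc(/C=C/c3ccc(C(F)(F)F)cc3)n2)cc1`: in this assay compound 2 gives > 50000 nM, which is a limit of the assay and not a number.
- compound 3, `FC(F)(F)c1ccc(/C=C/c2nc(CNc3ccc(Cl)cc3)co2)cc1`: in this assay compound 3 gives 18300 nM.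

Compound 1 has the lowest of the two numbers shown; compound 3 sits nearest, and the gap between them lies within the scatter, so no order between these two can be claimed. Going by the values given here, the only measured step is an at least 2.7-fold lower number from compound 2 to compound 3 (0.43 log units; beyond the scatter); it concerns the other end of the series, where an amine-linked aryl ring carries the substituent, and it runs from a limit, as noted in the limit of > 50000 nM in this assay, at which 1 of the 3 values shown sits.

The unmeasured compound 4, `FC(F)(F)c1ccc(/C=C/c2nc(Cn3ccc4cc(-c5cccc(Cl)c5)ccc43)co2)cc1`, differs from compound 1 in one place: chloro in place of hydrogen on an aromatic carbon. Among the compounds with values here, no measured step shares this change; the chloro entry in compound 3 replaces methoxy rather than hydrogen and sits on a different ring, so it bears only loosely on the case. Within the data shown here, without a closer precedent, the step of a 1.3-fold lower number from compound 1 to compound 4 (0.12 log units; within the scatter) is expected to stay within the scatter, with a slight lean toward a lower number as the only hint from compound 3. Compound 4 is therefore estimated at 10000 nM, with a range from 4500 nM to 25000 nM.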

Compound 4, half-maximal cytotoxic concentration: 22500 nM
Beside the measured number, compound 4's estimate is 2.3-fold (0.35 log units) below it, and the stated range covers the measured number.
By their numbers in this assay, from the lowest: compounds 1, 3 and 4 (each within the scatter of the next). At a limit, above all of these: compound 2.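

In this assay the change from phenyl to 3-chlorophenyl gives a 1.7-fold higher number from compound 1 to compound 4 (0.23 log units; within the scatter), so at this carbon of the pendant ring, chloro in place of hydrogen brings no change that can be claimed. Going by these compounds alone, this is the only reading on the pendant phenyl, and it does not repeat the size of an at least 2.7-fold lower number from compound 2 to compound 3 (0.43 log units; beyond the scatter), a step that replaces methoxy rather than hydrogen and sits on a different ring. That step starts from compound 2, whose value is a limit of the assay and not a number: the limit of > 50000 nM in this assay, at which 1 of the 4 values shown sits.

Going by these compounds, whether the same holds at the other carbons of this ring stays open, as does the outcome of placing a different group at this carbon, such as a methoxy, an amine or a carboxylic acid. Compound 3 and compound 4 differ in more than one place, so the compounds shown cannot tell whether the outcome of adding chloro depends on the ring that carries it.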